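The source may report more compounds than this note shows. Statements on the series, on what has been measured and on what is new or still open speak of the compounds shown alone.

Compound 1 `COc1ccc(-c2cc(=O)c3c(O)cc(OCCCCN4CCN(C)CC4)c(OC)c3o2)cc1` gives 4100 nM in a functional assay on B16 cells (Mus musculus) for cytotoxicity, read by MTT assay, with a stated time of 72 h; a higher number here means a weaker inhibitor, a lower number a stronger inhibitor. Compound 2 `COc1c(OCCCCN2CCN(C)CC2)cc(O)c2c(=O)cc(-c3ccc([N+](=O)[O-])cc3)oc12` gives 2890 nM in this assay.

Of the two measured compounds, compound 2 carries the lower number, yet the step of a 1.4-fold lower number from compound 1 to compound 2 (0.15 log units; within the scatter) lies within the scatter, so these two numbers cannot be told apart with any confidence.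

Compound 3 `COc1c(OCCCCN2CCN(C)CC2)cc(O)c2c(=O)cc(-c3ccc(F)cc3Br)oc12` has not yet been measured. It differs from compound 2 in a single place: 2-bromo-4-fluorophenyl in place of 4-nitrophenyl on an aromatic carbon. For the measured compounds named here, the only measured step available is a 1.4-fold lower number from compound 1 to compound 2 (0.15 log units; within the scatter), which also swapped one group on that same outer ring and gave no change beyond the scatter. Going by the values given here, no measured pair swaps a 4-nitrophenyl for a 2-bromo-4-fluorophenyl, so the data offer no ground for expecting a shift in either direction, and the one step seen on this ring argues for very little movement. Compound 3 is therefore expected to land near the number of compound 2 in this assay, estimated at 3000 nM with a range from 1000 nM to 9000 nM. The step this estimate implies, a 1.0-fold higher number from compound 2 to compound 3 (0.02 log units; within the scatter), is expected to stay within the scatter.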

Compound 3, half-maximal inhibitory concentration: 3440 nM
For compound 3 the middle estimate is 1.1-fold (0.06 log units) below the measured one; low and high end bracket the measured number.
By their numbers in this assay, from the lowest: compounds 2, 3 and 1 (each within the scatter of the next).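

At this position, the aromatic carbon next to the ring oxygen, replacing 4-nitrophenyl with 2-bromo-4-fluorophenyl gives in this assay a 1.2-fold higher number from compound 2 to compound 3 (0.08 log units; within the scatter) and so no change that can be distinguished from the scatter. Compared with the 4-methoxyphenyl group, the same ring gives a 1.2-fold lower number from compound 1 to compound 3 (0.08 log units; within the scatter) and again stays within the scatter, so three differently substituted phenyl rings now sit at this place without any separation in this assay. The earlier pair showed only that one substituent could replace another, whereas this result adds a ring carrying two halogens, and the change from a group with 2 hydrogen-bond acceptors to one with 0 likewise leaves the number within the scatter, though no available evidence accounts for this lack of separation.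

As far as these compounds go, what remains open is whether an amine or a carboxylic acid on the outer ring would produce a step beyond the scatter. From the compounds shown here alone, it is also open whether replacing the phenyl ring with a cyclohexyl ring, or placing a single bromine or fluorine on the phenyl ring, would separate compounds at this position.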